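A few compounds are considered here, and "the series" means these few. Any claim that something is new, unique, unknown or untested is made for them only; others in the source may bear on it.

Compound 1 `Fc1ccccc1NCn1nc(-c2ccc3c(c2)OCCO3)oc1=S` belongs to a small set of three measured relatives that share one core and differ only in the ring attached to an amine nitrogen. In a functional assay, with a stated time of 6 min (on this read-out higher numbers stand for weaker inhibition and lower numbers for stronger inhibition), compound 1 gives 6390 nM. Compound 2 `Fc1ccc(NCn2nc(-c3ccc4c(c3)OCCO4)oc2=S)cc1` gives 6480 nM in this assay, and compound 3 `S=c1oc(-c2ccc3c(c2)OCCO3)nn1CNc1ccc(Cl)cc1Cl` gives 8710 nM. Compound 1 carries the lowest of the three numbers, but every gap between them lies within the scatter of repeated measurement, so no order among them can be claimed. The measured steps are all small: a 1.0-fold higher number from compound 1 to compound 2 (0.01 log units; within the scatter), a 1.4-fold higher number from compound 1 to compound 3 (0.13 log units; within the scatter), and a 1.3-fold higher number from compound 2 to compound 3 (0.13 log units; within the scatter).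

Compound 4 `O=[N+]([O-])c1ccc(NCn2nc(-c3ccc4c(c3)OCCO4)oc2=S)cc1` has not yet been measured. It differs from compound 1 in one place: 4-nitrophenyl in place of 2-fluorophenyl on an amine nitrogen. All three measured steps bear on this change. Each of them also swapped the ring on that same amine nitrogen, and none of them moved the number beyond the scatter. Among the measured compounds shown here, there is no measured example of the entering group itself, so the expectation rests only on the pattern that ring swaps at this position left the number unchanged. For compound 4 the expected step is therefore a 1.0-fold higher number from compound 1 to compound 4 (0.01 log units; within the scatter), none beyond the scatter. Compound 4 is expected to give about 6500 nM in this assay, with a likely range from 3000 nM to 14000 nM.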

Compound 4, half-maximal inhibitory concentration: 9950 nM
Compound 4: middle estimate off by 1.5-fold (0.18 log units), on the low side, within the range that was stated.
By their numbers in this assay, from the lowest: compounds 1, 2, 3 and 4 (each within the scatter of the next).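

With a 1.6-fold higher number from compound 1 to compound 4 (0.19 log units; within the scatter) and a 1.1-fold higher number from compound 3 to compound 4 (0.06 log units; within the scatter) in this assay the four numbers remain within the scatter, so the ring on the amine nitrogen can now carry a nitro group, with hydrogen-bond acceptors that the halogen-bearing rings of compounds 1, 2 and 3 do not have, without a readable shift. The closest comparison is a 1.5-fold higher number from compound 2 to compound 4 (0.19 log units; within the scatter) in which only nitro stands in place of fluoro on an aromatic carbon, and it shows that even this single exchange on an otherwise identical ring leaves the result within the scatter. No independent measurement is available to explain why the numbers stay so close.

On these data alone, it remains open whether this insensitivity would hold for a ring bearing an amine or a carboxylic acid, or if a saturated cyclohexyl ring or an open alkyl chain replaced the aromatic ring on the amine nitrogen. Since all four compounds differ only in this ring, they also say nothing about how the number would respond to changes in the shared core.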